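This account rests on a few compounds, and the source may have more. Where it says the series, first, only, none or still open, it means among the compounds named here.

Working notes on the series. Compound 1 `COc1cc(-c2nn(-c3cccc(NC(=O)c4cccc(C(F)(F)F)c4)c3)cc2-c2ccncc2)ccc1Cl` carries an amide on the shared core and in a functional assay on NCI-H23 cells (Homo sapiens) for inhibition, read by sulforhodamine B assay, with a stated time of 48 h (on this read-out higher numbers stand for weaker inhibition of growth and lower numbers for stronger inhibition of growth), compound 1 gives 1560 nM. Compound 2 `COc1cc(-c2nn(-c3cccc(NC(=O)Nc4ccc(Cl)c(Cl)c4)c3)cc2-c2ccncc2)ccc1Cl` is a urea, and in this assay compound 2 gives 1410 nM. Compound 3 `COc1cc(-c2nn(-c3cccc(NC(=O)Nc4cccc(C(F)(F)F)c4)c3)cc2-c2ccncc2)ccc1Cl` is also a urea, and in this assay compound 3 gives 1180 nM, the lowest of the three numbers, though a 1.3-fold lower number from compound 1 to compound 3 (0.12 log units; within the scatter) and a 1.2-fold lower number from compound 2 to compound 3 (0.08 log units; within the scatter) both sit within the scatter, as does a 1.1-fold lower number from compound 1 to compound 2 (0.04 log units; within the scatter). The three measured compounds therefore cannot be separated from one another on this read-out.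

Compound 4 `COc1cc(-c2nn(-c3cccc(NC(=O)c4ccc(Cl)c(C(F)(F)F)c4)c3)cc2-c2ccncc2)ccc1Cl` is not yet measured. Relative to compound 3 the change is 4-chloro-3-(trifluoromethyl)phenyl in place of (3-(trifluoromethyl)phenyl)amino on a carbonyl carbon, so compound 4 returns to the amide linkage of compound 1 while carrying a 4-chloro-3-(trifluoromethyl)phenyl group. Among the measured compounds shown here, the only measured step across the amide-to-urea change is a 1.3-fold lower number from compound 1 to compound 3 (0.12 log units; within the scatter), and that step lay within the scatter, so the reverse change is not expected to move the number beyond the scatter either. For the measured compounds named here, no measured pair speaks to the chlorine that enters. The expectation for compound 4 in this assay is therefore a step of a 1.2-fold higher number from compound 3 to compound 4 (0.07 log units; within the scatter), that is, essentially no change. Compound 4 is estimated at 1400 nM, with a range from 700 nM to 2800 nM.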

Compound 4, concentration for 50% growth inhibition: 5390 nM
Beside the measured number, compound 4's estimate is 3.9-fold (0.59 log units) below it; measured number outside the range, above it.
By their numbers in this assay, from the lowest: compounds 3, 2 and 1 (each within the scatter of the next); then compound 4.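

Adding a chloro in place of hydrogen on an aromatic carbon of the amide gives the first step in the series to lie beyond the scatter in this assay: a 3.5-fold higher number from compound 1 to compound 4 (0.54 log units; beyond the scatter) and so shows that the amide aryl group is not indifferent to substitution, as the near-equal earlier numbers might have suggested. Against the ureas the picture is the same, with a 4.6-fold higher number from compound 3 to compound 4 (0.66 log units; beyond the scatter) and a 3.8-fold higher number from compound 2 to compound 4 (0.58 log units; beyond the scatter) both beyond the scatter, so compound 4 is the weakest of the four and the only one that separates from the rest, while the amide-to-urea change alone had stayed within the scatter between compound 1 and compound 3. No measurement shown accounts for this loss of growth inhibition.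

On these data alone, it remains open whether the rise belongs to chlorine itself or to any group on that aromatic carbon, which a fluoro, methyl or methoxy group in place of the chloro would test. As far as these compounds go, it is also open whether a urea bearing the same 4-chloro-3-(trifluoromethyl)phenyl group would show the same rise or would stay with compound 2 and compound 3.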